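Swapping the 4-cyanophenyl arm for a small heteroaryl cyclopropyl

The compounds below may be only part of what the source reports. "The series", "measured", "known", "first", "only" and "open" are said of these compounds alone.

Compound 1 `N#Cc1ccc(CN([C@H](CCC(F)(F)F)C(N)=O)S(=O)(=O)c2ccc(Cl)cc2)cc1` carries a 4-cyanophenyl group on the saturated chain carbon bound to the sulfonamide nitrogen; in an ADME assay on MDCKII-LE cells (Canis lupus familiaris) for permeability (a higher number here means that the compound crosses the layer faster, a lower number that the compound crosses the layer more slowly), compound 1 gives 19.7 10^-6 cm/s. Compound 2 `N#CCCCCN([C@H](CCC(F)(F)F)C(N)=O)S(=O)(=O)c1ccc(Cl)cc1` gives 24 10^-6 cm/s in this assay, and compound 3 `NC(=O)[C@@H](CCC(F)(F)F)N(CCCc1ncon1)S(=O)(=O)c1ccc(Cl)cc1` gives 31.3 10^-6 cm/s. Compound 1 holds the smallest of the three numbers, yet a 1.2-fold higher number from compound 1 to compound 2 (0.09 log units; within the scatter) and a 1.6-fold higher number from compound 1 to compound 3 (0.20 log units; within the scatter) both stay inside the scatter, as does a 1.3-fold higher number from compound 2 to compound 3 (0.12 log units; within the scatter); nothing in the three measured compounds separates beyond it.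

Compound 4 `NC(=O)[C@@H](CCC(F)(F)F)N(CC1(c2ncon2)CC1)S(=O)(=O)c1ccc(Cl)cc1` is the next step from compound 1: 1-(1,2,4-oxadiazol-3-yl)cyclopropyl in place of 4-cyanophenyl on a saturated chain carbon bound to a sulfonamide nitrogen. For the measured compounds named here, the closest precedent is compound 3, where a 1,2,4-oxadiazol-3-yl group also replaces the aromatic nitrile-bearing arm and the result is a 1.6-fold higher number from compound 1 to compound 3 (0.20 log units; within the scatter). On that basis compound 4 is expected to land close to compound 1, with a 1.4-fold higher number from compound 1 to compound 4 (0.14 log units; within the scatter) as the estimated step, no change beyond the scatter. The estimate for compound 4 in this assay is 27 10^-6 cm/s, within 16 10^-6 cm/s to 45 10^-6 cm/s.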

Compound 4, apparent permeability: 16.4 10^-6 cm/s
Beside the measured number, compound 4's estimate is 1.6-fold (0.22 log units) above it; measured number inside the range.
By their numbers in this assay, from the lowest: compounds 4, 1, 2 and 3 (each within the scatter of the next).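

In this assay, the saturated chain carbon bound to a sulfonamide nitrogen now takes a third kind of arm, one with a three-membered ring, with no step beyond the scatter: a 1.2-fold lower number from compound 1 to compound 4 (0.08 log units; within the scatter). The same holds against the two arms without that ring, with a 1.9-fold lower number from compound 3 to compound 4 (0.28 log units; within the scatter) and a 1.5-fold lower number from compound 2 to compound 4 (0.17 log units; within the scatter); the first of these is the largest step among the four compounds, yet it stays inside the scatter. Nothing available bears on why these four arms fall so close together.

Going by these compounds, all four arms carry a nitrile or a 1,2,4-oxadiazol-3-yl group, so whether a primary amine or a carboxylic acid on this arm would give a step beyond the scatter remains open. A longer chain between the sulfonamide nitrogen and the 1,2,4-oxadiazol-3-yl group is equally untested by these compounds.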